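This account rests on a few compounds, and the source may have more. Where it says the series, first, only, none or still open, it means among the compounds named here.

In a functional assay on RAW264.7 cells (Mus musculus) for inhibition, read by Griess assay, with stated times of 1 h and 24 h (a higher number here means a weaker inhibitor, a lower number a stronger inhibitor), three compounds built on a shared core have been measured. Compound 1 `CCOc1ccc(C(O)C2OC(=O)c3c(OC)cc(OC)cc32)cc1` gives > 10000 nM, which is a limit and not a number. Compound 2 `CCCCOc1ccc(C(O)C2OC(=O)c3c(OC)cc(OC)cc32)cc1` gives a true number, 1800 nM. Compound 3 `CCC(C)Oc1ccc(C(O)C2OC(=O)c3c(OC)cc(OC)cc32)cc1` gives > 10000 nM, again only a limit. That places compound 3 at the limit of > 10000 nM in this assay, at which 2 of the 3 values shown sit.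

Compound 4 `CCOCCOc1ccc(C(O)C2OC(=O)c3c(OC)cc(OC)cc32)cc1` has 2-ethoxyethyl in place of sec-butyl on an oxygen on an aromatic ring. Going by the values given here, two measured steps bear on this change. The ethyl extension gave an at least 5.5-fold lower number from compound 1 to compound 2 (0.74 log units; beyond the scatter), and sec-butyl in place of butyl gave an at least 5.5-fold higher number from compound 2 to compound 3 (0.74 log units; beyond the scatter). Among the compounds with values here, the new chain is unbranched, as is the butyl of compound 2 at 1800 nM, but it also brings a hydrogen-bond acceptor that no measured step tests. A modest move to a lower number is therefore expected in this assay, though compound 4 may well stay at the limit. The estimate for compound 4 is 6000 nM, with an expected range of 1500 nM to 20000 nM. This expectation amounts to an estimated at least 1.6-fold lower number from compound 3 to compound 4 (0.22 log units; that floor lies within the scatter).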

Compound 4, half-maximal inhibitory concentration: > 10000 nM
Compound 4 gave a limit, no number; the forecaster's own chance of this, stated with the estimate: 45%; at least 1.6-fold (0.22 log units) between middle value and limit.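

In this assay the 2-ethoxyethyl chain of compound 4 shows that being unbranched does not by itself keep a chain on this oxygen on an aromatic ring at the level of the butyl chain. Ethoxy in place of ethyl gives an at least 5.5-fold higher number from compound 2 to compound 4 (0.74 log units; beyond the scatter) and so counts against that reading as clearly as the sec-butyl change did. The steps from compound 3 to compound 4 and from compound 1 to compound 4 join two limits and cannot be read, and the butyl chain of compound 2 remains the only one here with a true number: the limit of > 10000 nM in this assay, at which 3 of the 4 values shown sit.

Going by these compounds, whether a longer chain such as pentyl or hexyl would give a lower number than butyl remains open. So does the effect of an amine or a carboxylic acid at the end of the chain.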